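The source may report more compounds than this note shows. Statements on the series, on what has been measured and on what is new or still open speak of the compounds shown alone.

Among the measured compounds shown here, compound 1 `CCn1cc(-c2nc3ccccc3[nH]2)c(=O)c2cc(F)c(N3CCNCC3)cc21` sits at the high end of the two numbers available so far: in a functional assay on AGS cells (Homo sapiens) for cytotoxicity, read by sulforhodamine B assay, with a stated time of 48 h (on this read-out higher numbers stand for weaker inhibition of growth and lower numbers for stronger inhibition of growth), compound 1 gives 9500 nM, while compound 2 `CCn1cc(-c2nc3ccccc3[nH]2)c(=O)c2cc(F)c(N3CCNCC3)nc21` gives 2100 nM in this assay, a lower number that lies beyond the scatter. Compound 3 `CCn1cc(-c2nc3ccc(Cl)cc3[nH]2)c(=O)c2cc(F)c(N3CCNCC3)cc21` differs from compound 1 in one place only: chloro in place of hydrogen on an aromatic carbon. For the measured compounds named here, nothing measured so far speaks to this change, so the expected step from compound 1 to compound 3 in this assay is small, at most a slight lowering, and it may not exceed the scatter at all: a 1.4-fold lower number from compound 1 to compound 3 (0.13 log units; within the scatter). Compound 3 is therefore expected near 7000 nM in this assay, within a range of 2500 nM to 20000 nM.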

Compound 3, concentration for 50% growth inhibition: 4500 nM
For compound 3 the middle estimate is 1.6-fold (0.19 log units) above the measured one; the measured number falls inside the stated range.
By their numbers in this assay, from the lowest: compound 2; then compound 3; then compound 1.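

In this assay, among the compounds shown here, the 6-chloro-1H-benzimidazol-2-yl group of compound 3 gives the first reading on substitution at this aromatic carbon (a 2.1-fold lower number from compound 1 to compound 3 (0.32 log units; beyond the scatter)). The position accepts a chlorine with no loss of growth inhibition, and the modest step runs towards stronger inhibition. No measurement at hand explains this step. Still open, as far as these compounds go, is whether fluoro, methoxy or an amine at this carbon would move the number in the same direction. Also open, from the compounds shown here alone, is whether chloro would give a similar step on the core of compound 2.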